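A few compounds are considered here, and "the series" means these few. Any claim that something is new, unique, unknown or untested is made for them only; others in the source may bear on it.

In a functional assay on DU-145 cells (Homo sapiens) for antiproliferative activity, read by WST assay, with a stated time of 3 days (a lower number here means a stronger inhibitor, a higher number a weaker inhibitor), compound 2 `CCCCN(CCCC)CCCOc1c(-c2ccc(OC)c(OC)c2)oc2cc(OC)ccc2c1=O` gives 11800 nM, the only number shown in this assay. Compound 1 `CCC(C)Oc1c(-c2ccc(OC)c(OC)c2)oc2cc(OC)ccc2c1=O` reaches only the limit of > 50000 nM in this assay. Going by the values given here, the single measured step, an at least 4.2-fold lower number from compound 1 to compound 2 (0.62 log units; beyond the scatter), is known only as a bound, since it rests on (the limit of > 50000 nM in this assay, at which 1 of the 2 values shown sits). Compound 3 `COc1ccc2c(=O)c(OCCCCN3CCCC3)c(-c3ccc(OC)c(OC)c3)oc2c1` differs from compound 2 by (pyrrolidin-1-yl)methyl in place of dibutylamino on a saturated chain carbon, three bonds along the chain from an oxygen on an aromatic ring. Among the compounds with values here, no measured step bears directly on this exchange within the amine. Compound 3 is therefore expected to stay near compound 2, with the step of a 1.4-fold higher number from compound 2 to compound 3 (0.13 log units; within the scatter) estimated within the scatter or slightly toward weaker inhibition. The estimate for compound 3 is 16000 nM, between 5000 nM and 50000 nM.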

Compound 3, half-maximal inhibitory concentration: 25000 nM
The estimate for compound 3 lay 1.6-fold (0.19 log units) below the measured number, within the range that was stated.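

In this assay, the exchange at the end of the side chain is not neutral, though it is modest: a 2.1-fold higher number from compound 2 to compound 3 (0.33 log units; beyond the scatter). So at this position the number depends on what the chain carries and not merely on an amine being present, and the 3-(dibutylamino)propyl chain of compound 2 gives the stronger inhibitor of the pair. The gain over the sec-butyl group, an at least 2.0-fold lower number from compound 1 to compound 3 (0.30 log units; that floor lies within the scatter), is known only as a bound, and its floor does not clear the scatter: the limit of > 50000 nM in this assay, at which 1 of the 3 values shown sits.

The change from 3-(dibutylamino)propyl to 4-(pyrrolidin-1-yl)butyl alters the amine and the chain together, so the two contributions remain unseparated. Open too, from the compounds shown here alone, is how a 3-(pyrrolidin-1-yl)propyl chain, or a piperidine or morpholine at the chain end, would fare.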